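The source may hold more compounds than are shown below. What is called first, only, known or untested is meant among the compounds shown, and "the series" means these compounds.

Measured compounds in a physicochemical assay for solubility; on this read-out lower numbers stand for lower solubility and higher numbers for higher solubility:
compound 1, `C[C@H](Nc1ccc(C#N)n(C)c1=O)c1cc2cc(Cl)c(F)cc2[nH]c1=O`: 18000 nM
compound 2, `C[C@H](Nc1ccc(C#N)n(C)c1=O)c1cc2cc(Cl)c(OCc3ccccn3)cc2[nH]c1=O`: 2500 nM

Compound 2 stands at the lower of the two numbers in this assay. Within the data shown here, its only measured neighbour is compound 1, and the single change between them, (pyridin-2-yl)methoxy in place of fluoro on an aromatic carbon, gave a 7.2-fold lower number from compound 1 to compound 2 (0.86 log units; beyond the scatter).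

Compound 3, `C[C@H](Nc1ccc(C#N)n(C)c1=O)c1cc2cc(Cl)c(O[C@H](C)c3ccccn3)cc2[nH]c1=O`, has not yet been measured in this assay. It differs from compound 2 by methyl in place of hydrogen on a saturated chain carbon bound to an aromatic carbon and an oxygen on an aromatic ring.

Among the measured compounds shown here, the one measured step concerns another place on the shared core and another group, so it bears only loosely on this change; no step among the measured compounds shows methyl in place of hydrogen on a saturated chain carbon bound to an aromatic carbon and an oxygen on an aromatic ring. What can be said is that the entering group is small and without donors or acceptors, and the step from compound 1 to compound 2 was of modest size for a far larger change. The expected step for compound 3 is therefore a 1.3-fold lower number from compound 2 to compound 3 (0.10 log units; within the scatter), no further than the scatter, in either direction. Compound 3 is estimated at 2000 nM in this assay, with a range from 700 nM to 6000 nM.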

Compound 3, solubility: 1600 nM
Compound 3: the middle estimate sits 1.3-fold (0.10 log units) above what was measured, and the stated range covers the measured number.
By their numbers in this assay, from the lowest: compounds 3 and 2 (each within the scatter of the next); then compound 1.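

In this assay the saturated chain carbon bound to an aromatic carbon and an oxygen on an aromatic ring now has a step of its own: methyl in place of hydrogen gives a 1.6-fold lower number from compound 2 to compound 3 (0.19 log units; within the scatter) and so cannot be told apart from no change on this read-out. Read as one replacement, the whole change from the fluoro group gives an 11-fold lower number from compound 1 to compound 3 (1.05 log units; beyond the scatter) and is thus beyond the scatter, so among these compounds the separation from compound 1 is carried by the larger replacement and not shown to depend on the added methyl. Nothing measured here gives a reason for either step.

The compounds shown leave open whether an ethyl or a hydroxymethyl group on this same chain carbon, or the opposite configuration of the 1-(pyridin-2-yl)ethoxy group, would take the number beyond the scatter of compound 2. They also leave open how much of the separation from compound 1 depends on the pyridine ring, which a plain phenyl ring in its place would address.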